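The source may hold more compounds than are shown below. What is called first, only, known or untested is meant among the compounds shown, and "the series" means these compounds.

In a functional assay on CHO cells with adenosine receptor A1 (Homo sapiens) as the target, read by cAMP accumulation and immunoassay, with a stated time of 6 min, tested at 0.1 uM (a higher number here means a weaker effect of the compound at the concentration tested, a lower number a stronger effect), three compounds built on a shared core have been measured. Compound 1 `Nc1scc(CN2CCN(c3ccc(Cl)cc3F)CC2)c1C(=O)c1ccc(Cl)cc1` gives -9.4%, and compound 2 `Nc1scc(CN2CCN(c3c(F)cccc3F)CC2)c1C(=O)c1cccc(C(F)(F)F)c1` gives 1.3%. Compound 3 `Nc1scc(CN2CCN(C3CCCCCC3)CC2)c1C(=O)c1ccc(Cl)cc1` gives 13%, the highest of the three numbers; compound 2 sits nearest, below it beyond the scatter, and compound 1 lies furthest, also beyond the scatter.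

Compound 4 `Nc1scc(CN2CCN(c3c(F)cccc3F)CC2)c1C(=O)c1ccc(Cl)cc1` is the compound that has not yet been measured. It differs from compound 3 in one place: 2,6-difluorophenyl in place of cycloheptyl on an amine nitrogen in a ring.

Among the measured compounds shown here, one measured step bears directly on this change. Going from compound 1 to compound 3, cycloheptyl replaced 4-chloro-2-fluorophenyl on the ring nitrogen, and the number moved a number 22.4 percentage points higher from compound 1 to compound 3 (beyond the scatter). The step to compound 4 reverses that kind of exchange, putting an aromatic group back in place of cycloheptyl, so the number is expected to fall by a modest amount, beyond the scatter. Compound 2 also carries 2,6-difluorophenyl on the ring nitrogen, though it differs from compound 4 elsewhere, and its value sits well below that of compound 3.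

Compound 4 is therefore expected to give about -3% in this assay, within a range of -15% to 10%, an estimated step of a number 16 percentage points lower from compound 3 to compound 4 (beyond the scatter) from compound 3.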

Compound 4, a percentage reported as activity, at one concentration (the size of the read-out at that concentration, not a potency): -23%
Compound 4: the middle estimate sits 20 percentage points above what was measured; measured number below the stated range.
By their numbers in this assay, from the lowest: compound 4; then compound 1; then compound 2; then compound 3.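

In this assay, the exchange on the amine nitrogen in a ring gives a number 36 percentage points lower from compound 3 to compound 4 (beyond the scatter) when 2,6-difluorophenyl replaces cycloheptyl, and the aromatic groups at this position also differ from one another, with a number 13.6 percentage points lower from compound 1 to compound 4 (beyond the scatter) for 2,6-difluorophenyl in place of 4-chloro-2-fluorophenyl. The earlier step of a number 22.4 percentage points higher from compound 1 to compound 3 (beyond the scatter) could not separate these aromatic groups, so the read-out at this position depends on which aromatic group is present and not only on an aromatic ring replacing cycloheptyl. With 2,6-difluorophenyl held fixed, the group on the carbonyl carbon matters too, since 4-chlorophenyl in place of 3-(trifluoromethyl)phenyl gives a number 24.3 percentage points lower from compound 2 to compound 4 (beyond the scatter), and no data at hand account for any of these steps.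

The compounds shown leave open whether a pyridine ring, a morpholine or a simple benzyl group on that nitrogen would follow the aromatic groups or cycloheptyl. Because each number comes from one concentration, they also leave open how these steps would translate into potency, and whether 2,6-difluorophenyl would keep its edge with a 4-methoxyphenyl on the carbonyl carbon.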